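The source may hold more compounds than are shown below. What is called first, only, known or untested is meant among the compounds shown, and "the series" means these compounds.

Of the compounds shown here, three built on one shared core have been tested in an ADME assay on MT4 cells (Homo sapiens) for cytotoxicity, read by MTT assay, with a stated time of 5 days; a higher number here means that more compound is tolerated, a lower number that less compound is tolerated. Compound 1 `Cc1cc(/C=C/C#N)cc(C)c1Oc1nc(Nc2ccc(CN3CCN(S(C)(=O)=O)CC3)cc2)nc2sccc12` gives 131000 nM. Compound 2 `Cc1cc(/C=C/C#N)cc(C)c1Oc1nc(Nc2ccc(N3CCCC(NS(C)(=O)=O)C3)cc2)nc2sccc12` gives 112000 nM; the two numbers sit within the scatter of each other, as shown by a 1.2-fold lower number from compound 1 to compound 2 (0.07 log units; within the scatter). Compound 3 `Cc1cc(/C=C/C#N)cc(C)c1Oc1nc(Nc2ccc(N3CCCC(N)C3)cc2)nc2sccc12` gives 4610 nM, the lowest of the three numbers. The steps of a 28-fold lower number from compound 1 to compound 3 (1.45 log units; beyond the scatter) and a 24-fold lower number from compound 2 to compound 3 (1.39 log units; beyond the scatter) both lie beyond the scatter, so compound 3 is the one of which the cells tolerate the least.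

Compound 4 `Cc1cc(/C=C/C#N)cc(C)c1Oc1nc(Nc2ccc(N3CCNCC3)cc2)nc2sccc12` has not yet been measured in this assay. It differs from compound 3 in one place: piperazin-1-yl in place of 3-aminopiperidin-1-yl on an aromatic carbon. Among the compounds with values here, the one measured step that bears on this change is a 24-fold lower number from compound 2 to compound 3 (1.39 log units; beyond the scatter), where a hydrogen in place of methylsulfonyl on an amine nitrogen lowered the number sharply. Within the data shown here, compound 4 keeps a free amine in its ring, as compound 3 does, and the change from 3-aminopiperidin-1-yl to piperazin-1-yl has no direct counterpart among the measured pairs. The step from compound 3 to compound 4 is therefore expected to be small, a 1.1-fold higher number from compound 3 to compound 4 (0.04 log units; within the scatter), within the scatter. Compound 4 is expected to give 5000 nM, with a range from 1500 nM to 16000 nM.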

Compound 4, half-maximal cytotoxic concentration: 4740 nM
The estimate for compound 4 lay 1.1-fold (0.02 log units) above the measured number; low and high end bracket the measured number.
By their numbers in this assay, from the lowest: compounds 3 and 4 (each within the scatter of the next); then compounds 2 and 1 (each within the scatter of the next).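

In this assay, the step of a 1.0-fold higher number from compound 3 to compound 4 (0.01 log units; within the scatter) shows that 3-aminopiperidin-1-yl and piperazin-1-yl cannot be told apart at this aromatic carbon, para to a large group, even though the entering ring is one heavy atom smaller and holds 2 hetero atoms rather than 1. Compound 4 also sits far from the compounds that carry methylsulfonyl, with a 24-fold lower number from compound 2 to compound 4 (1.37 log units; beyond the scatter) and a 28-fold lower number from compound 1 to compound 4 (1.44 log units; beyond the scatter) both beyond the scatter, so among these four compounds the two with methylsulfonyl give the high numbers and the two with a free amine give the low numbers, and no compound goes against this. No measured finding is at hand to account for the match between the two rings or for the gap to the methylsulfonyl compounds.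

Still open, as far as these compounds go, is whether a methyl or acetyl group on the free ring nitrogen of compound 4 would raise the number as far as methylsulfonyl does on the amine of compound 2. Also open, from the compounds shown here alone, is whether a morpholine ring, which has oxygen in place of that nitrogen, would stay with compound 3 and compound 4 or move away from them.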